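The source may report more compounds than this note shows. Statements on the series, on what has been measured and on what is new or still open speak of the compounds shown alone.

Measured so far:
Compound 1 `c1ccc(-c2ccc(-c3ccc(-c4nc5ccccc5[nH]4)cc3)cc2)cc1`: 39700 nM
Compound 2 `FC(F)(F)Oc1ccc(-c2ccc(-c3ccc(-c4nc5ccccc5[nH]4)cc3)cc2)cc1`: 39100 nM

In a functional assay on KB cells (Homo sapiens) for inhibition, read by sulforhodamine B assay (a lower number here means a stronger inhibitor of growth, a higher number a weaker inhibitor of growth), compound 2 gives 39100 nM, level with compound 1 at 39700 nM, since the two values lie within the usual scatter. Compound 3 `COc1ccc(-c2ccc(-c3ccc(-c4nc5ccccc5[nH]4)cc3)cc2)cc1` has not yet been measured. It differs from compound 2 by one change, methyl in place of trifluoromethyl on an oxygen on an aromatic ring, which turns trifluoromethoxy into methoxy.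

Going by the values given here, only one measured step bears on this. Putting trifluoromethoxy in place of hydrogen on an aromatic carbon gave a 1.0-fold lower number from compound 1 to compound 2 (0.01 log units; within the scatter), so that change left the growth-inhibition number within the scatter. A single step is thin evidence, but it gives no reason to expect a shift in either direction beyond the scatter. The estimate amounts to a 1.1-fold lower number from compound 2 to compound 3 (0.05 log units; within the scatter), an expected step that stays within the scatter. For compound 3 the expected value is 35000 nM, with an estimated range of 17000 nM to 70000 nM.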

Compound 3, concentration for 50% growth inhibition: 47200 nM
Beside the measured number, compound 3's estimate is 1.3-fold (0.13 log units) below it, and the stated range covers the measured number.
By their numbers in this assay, from the lowest: compounds 2, 1 and 3 (each within the scatter of the next).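

In this assay, methyl in place of trifluoromethyl on the oxygen gives a 1.2-fold higher number from compound 2 to compound 3 (0.08 log units; within the scatter), while methoxy in place of hydrogen on an aromatic carbon gives a 1.2-fold higher number from compound 1 to compound 3 (0.08 log units; within the scatter). This position has now carried hydrogen, trifluoromethoxy and methoxy, and the three compounds cannot be told apart in this test, so replacing the fluorines of the oxygen-linked group with hydrogens has no readable effect on the growth-inhibition number. No supporting data are available to explain this flat result.

Three groups are too few to show that this position tolerates every change, so an amine, a carboxylic acid or a longer chain on the oxygen could still behave differently. As far as these compounds go, whether any change here can move the number beyond the scatter remains open.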